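The source may hold more compounds than are shown below. What is called first, only, known or untested is meant among the compounds shown, and "the series" means these compounds.

The measured compounds:
Compound 1, `O=C(O)CCc1ccc(-c2ccc3cnn(-c4ccccn4)c3c2)cc1`: 106%
Compound 2, `O=C(O)CCc1ccc(-c2cc(F)c3cnn(-c4ccccn4)c3c2)cc1`: 126%
Compound 3, `COc1nn(-c2ccccn2)c2cc(-c3ccc([C@H]4C[C@@H]4C(=O)O)cc3)cc(F)c12`: 19%

All three values come from a functional assay on cells for agonist activity at Free fatty acid receptor 1 (Mus musculus), read by FLIPR and calcium flux, with a stated time of 5 min; on this read-out lower numbers stand for smaller maximal responses and higher numbers for larger maximal responses. In this assay compound 2 gives 126%, and compound 1 gives 106%. These two differ in one place, (hydrogen in place of fluoro on an aromatic carbon), and the step between them is a number 20 percentage points lower from compound 2 to compound 1 (beyond the scatter). Compound 3 is built on another core; in this assay compound 3 gives 19%, the lowest of the three values. The difference between the core of compound 3 and the core of compound 2 is not broken down here.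

Compound 4, `COc1nn(-c2ccccn2)c2cc(-c3ccc([C@H]4C[C@@H]4C(=O)O)cc3)ccc12`, has not been measured. It differs from compound 3 by hydrogen in place of fluoro on an aromatic carbon. This is the same change as the one from compound 2 to compound 1, at a place described in the same words, and it occurs twice among the compounds shown. The earlier step, a number 20 percentage points lower from compound 2 to compound 1 (beyond the scatter), was beyond the scatter but modest. Compound 3 already stands low, and its value of 19% leaves little room for a drop of the same size. For compound 4 the step from compound 3 is expected to be a number 9 percentage points lower from compound 3 to compound 4 (within the scatter), in the same direction as before but smaller, resting on the earlier step and on the low starting value. Compound 4 is therefore estimated at 10%, with a range from 0% to 30%.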

Compound 4, largest response reached (reported as efficacy), in percent of the reference or control that the assay uses: 1%
Estimate against measurement, compound 4: 9 percentage points above; the measured number falls inside the stated range.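

In this assay hydrogen in place of fluoro on an aromatic carbon gave a number 18 percentage points lower from compound 3 to compound 4 (beyond the scatter) and so ran the same way as on the other core, with a size that matches the earlier step: the same change on two cores in this assay, a number 20 percentage points lower (beyond the scatter) from compound 2 to compound 1 and a number 18 percentage points lower (beyond the scatter) from compound 3 to compound 4, 2 percentage points apart, within the scatter of two such steps.

On one core compound 2 gives 126% and compound 1 gives 106%; on the other compound 3 gives 19% and compound 4 gives 1%, so in these two pairs the loss of fluoro carried across in percentage points from a high pair of values to a low one. This rests on just two pairs, one place and one read-out of maximal response, and it does not show that the step would hold on any further core, nor does it say why the step takes this size.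

The compounds shown leave open whether chloro or methyl on that aromatic carbon would move the response in the same way as fluoro. Going by these compounds alone, also open is which part of the difference between the two cores goes with their very different values, since no compound here separates those changes one place at a time.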